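A few compounds are considered here, and "the series" means these few. Any claim that something is new, unique, unknown or untested is made for them only; others in the source may bear on it.

Measured compounds in an ADME assay on L02 cells (Homo sapiens) for antiproliferative activity, read by MTT assay, with a stated time of 48 h; on this read-out higher numbers stand for weaker inhibition and lower numbers for stronger inhibition:

Compound 1, `CC(=O)Nc1ccc(-n2nncc2CN2C(=O)C3(C(C#N)=C(N)Oc4c(N)cc5nc6ccccc6nc5c43)c3ccccc32)cc1`: > 50000 nM, a limit of the assay rather than a number.
Compound 2, `Cc1cc(C)cc(-n2nncc2CN2C(=O)C3(C(C#N)=C(N)Oc4c(N)cc5nc6ccccc6nc5c43)c3ccccc32)c1`: > 50000 nM, likewise a limit of the assay.
Compound 3, `N#CC1=C(N)Oc2c(N)cc3nc4ccccc4nc3c2C12C(=O)N(Cc1cnnn1-c1c(F)cccc1F)c1ccccc12`: > 50000 nM, again a limit of the assay.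

Compound 3 therefore stands where every measured compound in this assay stands, at the limit described by the limit of > 50000 nM in this assay, at which 3 of the 3 values shown sit; no measured number separates it from the other two.

The step to compound 4, `N#CC1=C(N)Oc2c(N)cc3nc4ccccc4nc3c2C12C(=O)N(Cc1cnnn1-c1cc(Cl)ccc1Cl)c1ccccc12`, is 2,5-dichlorophenyl in place of 2,6-difluorophenyl on an aromatic nitrogen. The measured steps at the same position are a step that the two limits leave unreadable from compound 1 to compound 2, a step that the two limits leave unreadable from compound 1 to compound 3 and a step that the two limits leave unreadable from compound 2 to compound 3. Because all three values sit at the limit of the limit of > 50000 nM in this assay, at which 3 of the 3 values shown sit, none of these steps can be given a size; they show only that three quite different aryl groups on the aromatic nitrogen all left the value beyond the range this assay reports. There is thus no basis for expecting the change from a difluorophenyl to a dichlorophenyl group to bring the value into the measurable range.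

Compound 4 is accordingly expected to give about 60000 nM, within 30000 nM to 200000 nM, most probably reported again only as a limit. The estimated step that the limit leaves unreadable from compound 3 to compound 4 is expected to be nothing beyond the scatter.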

Compound 4, half-maximal inhibitory concentration: > 50000 nM
Compound 4 ended at the assay's limit (the forecaster's own chance of this, stated with the estimate: 80%); the middle value is on the limit's open side.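

In this assay, no step can be read between compound 4 and compound 1, compound 2 or compound 3, because all four values are limits of the assay rather than numbers: the limit of > 50000 nM in this assay, at which 4 of the 4 values shown sit. The compounds shown leave open how far apart these four compounds truly lie and whether any aryl group on this aromatic nitrogen gives a measurable value.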